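This account rests on a few compounds, and the source may have more. Where it says the series, first, only, none or still open, it means among the compounds named here.

Compound 3 `Cc1ccc(CO/N=C2/C(c3c[nH]c4ccccc34)=Nc3ccccc32)cc1` belongs to a small set of three measured analogues sharing one core. In a functional assay on MGC-803 cells (Homo sapiens) for cytotoxicity, read by MTT assay, with a stated time of 2 days (a higher number here means a weaker inhibitor, a lower number a stronger inhibitor), compound 3 gives 22800 nM, the highest number among the three. Compound 2 `Fc1ccc2c(c1)/C(=N\OCc1ccccc1)C(c1c[nH]c3ccc(F)cc13)=N2` gives 21300 nM in this assay, a number that sits within the scatter of that of compound 3, so the two cannot be ranked against each other. Among the compounds with values here, compound 1 `O=[N+]([O-])c1ccc2c(c1)/C(=N\O)C(c1c[nH]c3ccc([N+](=O)[O-])cc13)=N2` gives 10800 nM in this assay, which is a lower number than that of compound 3 by a margin beyond the scatter; no single-point step links compound 1 to compound 3, so only the two values themselves are known.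

Compound 4 `FC(F)(F)c1ccc(CO/N=C2/C(c3c[nH]c4ccccc34)=Nc3ccccc32)cc1` is not yet measured. It differs from compound 3 by trifluoromethyl in place of methyl on an aromatic carbon. Within the data shown here, no pair among the measured compounds carries this change, so nothing in the set says how large a step it brings. The expectation is therefore a step from compound 3 to compound 4 of a 1.3-fold lower number from compound 3 to compound 4 (0.10 log units; within the scatter), one that is not expected to pass beyond the scatter in either direction. On that basis compound 4 is estimated to give 18000 nM in this assay, with a range from 8000 nM to 40000 nM.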

Compound 4, half-maximal inhibitory concentration: 30600 nM
For compound 4 the middle estimate is 1.7-fold (0.23 log units) below the measured one, and the stated range covers the measured number.
By their numbers in this assay, from the lowest: compounds 1, 2, 3 and 4 (each within the scatter of the next, the first and the last beyond it).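

In this assay, the exchange of methyl for trifluoromethyl on an aromatic carbon, para to a large group, turning 4-methylphenyl into 4-(trifluoromethyl)phenyl, amounts to a 1.3-fold higher number from compound 3 to compound 4 (0.13 log units; within the scatter) and gives the set its first step between compounds that differ in one place. Where the earlier compounds offered only separate values, this pair shows directly that this change at this position does not carry the number beyond the scatter, so compound 3 and compound 4 cannot be ranked against each other. Nothing measured here bears on why the two compounds read as they do.

The compounds shown leave open whether a different group at this position, such as an amine, a carboxylic acid or a longer chain, would give a step beyond the scatter, since this single pair tests only one exchange on one scaffold. They also leave open whether the same exchange would behave alike on the core of compound 2, which carries fluorine on both ring systems, and which of the several differences sets compound 1 apart from compound 3.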